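Fluoro in Place of Nitro on the Fused Ring

The compounds below may be only part of what the source reports. "The series", "measured", "known", "first", "only" and "open" are said of these compounds alone.

Compound 3 `O=[N+]([O-])c1ccc2c(c1)CCN2S(=O)(=O)c1ccc(-c2cnc(C3CC3)o2)cc1` was tested in an ADME assay on HEK-293T cells (Homo sapiens) for inhibition, read by MTT assay, tested at 10 uM (on this read-out higher numbers stand for more inhibition at the one concentration tested (going by the name of the read-out) and lower numbers for less inhibition), where compound 3 gives 48.4%. Among the three numbers measured so far, compound 3 stands second. Compound 1 `CC1Cc2ccccc2N1S(=O)(=O)c1ccc(-c2cnc(C3CC3)o2)cc1` lies above it beyond the scatter: in this assay compound 1 gives 61.3%. Compound 2 `CS(=O)(=O)c1ccc2c(c1)CCN2S(=O)(=O)c1ccc(-c2cnc(C3CC3)o2)cc1` lies far below, as in this assay compound 2 gives 6.54%. Compound 4 `O=S(=O)(c1ccc(-c2cnc(C3CC3)o2)cc1)N1CCc2cc(F)ccc21` has not yet been measured. It differs from compound 3 in a single place: fluoro in place of nitro on an aromatic carbon. Among the compounds with values here, the only measured step touching this position is a number 41.9 percentage points higher from compound 2 to compound 3 (beyond the scatter), a large change showing that the read-out answers strongly to the group placed there, but no measured step exchanges nitro for fluoro, so the direction for compound 4 is open. Compound 4 is expected to land between the values of compound 2 and compound 1, with 50% as the estimate and a range from 25% to 75%. The expected step of a number 1.6 percentage points higher from compound 3 to compound 4 (within the scatter) need not exceed the scatter.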

Compound 4, a percentage reported as inhibition, at one concentration (the size of the read-out at that concentration, not a potency): 25.7%
Compound 4: the middle estimate sits 24.3 percentage points above what was measured; measured number inside the range.
By their numbers in this assay, from the lowest: compound 2; then compound 4; then compound 3; then compound 1.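

Fluoro in place of nitro on this aromatic carbon gives a number 22.7 percentage points lower from compound 3 to compound 4 (beyond the scatter), the first measured exchange at this position that starts from nitro, and it shows that nitro is not simply replaceable here without a loss in the number. Fluoro in place of methylsulfonyl gives a number 19.2 percentage points higher from compound 2 to compound 4 (beyond the scatter), so the three groups tried at this position order themselves in this assay with methylsulfonyl lowest, fluoro in the middle and nitro highest, each separated from the others beyond the scatter. Nothing available accounts for this order.

On these data alone, whether an amine or a carboxylic acid on the same aromatic carbon would fall inside this spread or outside it remains open. As far as these compounds go, it is also open whether the same order of groups would hold on the core of compound 1.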